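Swapping a methoxy for a cyano on the outer ring

This account rests on a few compounds, and the source may have more. Where it says the series, first, only, none or still open, it means among the compounds named here.

Measured so far:
Compound 1 `O=C(NC1CCN(Cc2ccc(Cl)c(Cl)c2)CC1)c1csc([N+](=O)[O-])c1`, which in a functional assay on HEK293 cells for antagonist activity at melanin-concentrating hormone receptor 1 (Homo sapiens), read by GTPgammaS binding (a higher number here means a weaker inhibitor, a lower number a stronger inhibitor), gives 804 nM.
Compound 2 `COc1ccc(-n2ccc(CN3CCC(NC(=O)COc4cccc(Cl)c4)CC3)c2)cc1`, which in this assay gives 90 nM.

For the measured compounds named here, of these two, compound 2 has the lower number and is therefore the stronger inhibitor; the gap to compound 1 lies well beyond the usual scatter, so the order can be trusted, although with only two compounds nothing more general can be drawn.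

Compound 3 `N#Cc1ccc(-n2ccc(CN3CCC(NC(=O)COc4cccc(Cl)c4)CC3)c2)cc1` is the next compound to consider, and it has not yet been measured. It differs from compound 2 in one place only: cyano in place of methoxy on an aromatic carbon. The rest of the molecule, including the amide, the linker and the chlorinated outer ring, is untouched.

Going by the values given here, no pair of measured compounds shows this kind of swap, so the size of the step is uncertain. Because compound 2 already gives 90 nM, the expectation is that compound 3 stays close to it, with a step from compound 2 to compound 3 of about a 1.2-fold higher number from compound 2 to compound 3 (0.09 log units; within the scatter), which is not beyond the scatter. Compound 3 is accordingly estimated at 110 nM, within a range of 35 nM to 350 nM.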

Compound 3, half-maximal inhibitory concentration: 145 nM
Compound 3: the middle estimate sits 1.3-fold (0.12 log units) below what was measured; the range from low to high includes it.
By their numbers in this assay, from the lowest: compounds 2 and 3 (each within the scatter of the next); then compound 1.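

In this assay, going from 4-methoxyphenyl to 4-cyanophenyl gives a 1.6-fold higher number from compound 2 to compound 3 (0.21 log units; within the scatter), so the two compounds cannot be told apart. For the compounds shown here, this is the first direct look at this position, on the six-membered aromatic ring and para to a large group, and it shows that methoxy and cyano, each with two heavy atoms and one hydrogen-bond acceptor, can occupy it without a change that rises above the scatter. Nothing available here explains why these two groups read alike, and a single pair cannot show whether the position is generally forgiving.

The compounds shown leave open what this position does with a plain hydrogen, a halogen such as fluorine, an amine, a carboxylic acid or a longer chain such as butoxy, any of which could reveal a limit that methoxy and cyano do not reach. Compound 1 differs from compound 2 and compound 3 in more than one place, so it cannot help answer that question.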